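Naphthyl trimethoxyphenyl carbinols: notes toward compound 4

This account rests on a few compounds, and the source may have more. Where it says the series, first, only, none or still open, it means among the compounds named here.

Three members of this series have been tested in a functional assay on HCT-116 cells (Homo sapiens) for inhibition, read by sulforhodamine B assay, with a stated time of 48 h; a lower number here means a stronger inhibitor, a higher number a weaker inhibitor. Compound 1 `CCOC(=O)C(C)C(O)(c1ccc(OC)c(OC)c1OC)c1cccc2ccccc12` gives only a limit of the assay there, > 20000 nM. Compound 2 `COc1ccc(C(c2ccccc2O)c2cccc3ccccc23)c(OC)c1OC` likewise gives only a limit, > 20000 nM. Compound 3 `COc1ccc(/C(=N/OC(C)=O)c2cccc3ccccc23)c(OC)c1OC` gives a number, 4980 nM. Compound 1 therefore stands at the weak end of what is shown, sitting at the limit of > 20000 nM in this assay, at which 2 of the 3 values shown sit, together with compound 2. Going by the values given here, no pair of measured compounds differs in a single place, so no measured step is available to calibrate the size of a change in this assay.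

Compound 4 `COc1ccc(C(O)(C/C=C\c2ccccc2)c2cccc3ccccc23)c(OC)c1OC` is the next member to be measured. It differs from compound 1 in one place: 3-phenylprop-2-en-1-yl in place of 1-(ethoxycarbonyl)ethyl on a saturated chain carbon bound to two aromatic carbons and an oxygen on a saturated carbon. A modest step toward stronger inhibition in this assay is expected, an at least 2.0-fold lower number from compound 1 to compound 4 (0.30 log units; that floor lies within the scatter), since compound 3 shows that a non-ester member of the shared core can give a number at 4980 nM. Compound 4 is expected to give roughly 10000 nM, within a range of 2000 nM to 40000 nM. A limit rather than a number remains a real possibility.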

Compound 4, half-maximal inhibitory concentration: > 20000 nM
Compound 4 was reported as a limit (the forecaster's own chance of this, stated with the estimate: 45%); middle value at least 2.0-fold (0.30 log units) from the limit.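

Going by these compounds alone, compound 1 and compound 4 are both reported only as limits in this assay, so no step between them can be read. Left open is how 3-phenylprop-2-en-1-yl and 1-(ethoxycarbonyl)ethyl compare at this place, since both compounds rest at one value: the limit of > 20000 nM in this assay, at which 3 of the 4 values shown sit.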